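Removing a second benzyl group from a sugar-based Substance-K receptor ligand

A few compounds are considered here, and "the series" means these few. Any claim that something is new, unique, unknown or untested is made for them only; others in the source may bear on it.

Compound 1 `CCOC(=O)C1=C(C)OC2OC(COCc3ccccc3)C(OCc3ccccc3)C(OCc3ccccc3)C2S1` was tested in an assay on CHO cells for displacement of a labelled ligand from Substance-K receptor (Homo sapiens) (on this read-out lower numbers stand for stronger inhibition and higher numbers for weaker inhibition), where compound 1 gives 12600 nM. Compound 2 `CCOC(=O)C1=C(C)OC2OC(CO)C(OCc3ccccc3)C(OCc3ccccc3)C2S1` differs from it by hydrogen in place of benzyl on an oxygen on a saturated carbon, and in this assay compound 2 gives 4000 nM; this made a 3.2-fold lower number from compound 1 to compound 2 (0.50 log units; beyond the scatter). Compound 3 `CCOC(=O)C1=C(C)OC2OC(CO)C(OCc3ccccc3)C(OCc3ccccc3)C2[S+]1[O-]` gives 4000 nM in this assay, level with compound 2. The difference between the cores of compound 3 and compound 1 is not broken down here. Compound 4 `CCOC(=O)C1=C(C)OC2OC(CO)C(OCc3ccccc3)C(O)C2[S+]1[O-]` is not yet measured; it differs from compound 3 by hydrogen in place of benzyl on an oxygen on a saturated carbon. This is the same kind of change as from compound 1 to compound 2, but the oxygen's other neighbour is here a saturated ring carbon rather than a saturated chain carbon. Resting on a 3.2-fold lower number from compound 1 to compound 2 (0.50 log units; beyond the scatter), a similar but uncertain step is expected, a 2.0-fold lower number from compound 3 to compound 4 (0.30 log units; within the scatter), so compound 4 is estimated at 2000 nM in this assay, between 700 nM and 6000 nM.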

Compound 4, inhibition constant: > 10000 nM
Compound 4: a limit, no number; the forecaster's own chance of this, stated with the estimate: 5%; at least 5.0-fold (0.69 log units) between middle value and limit.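

Replacing benzyl with hydrogen on an oxygen gave an at least 2.5-fold higher number from compound 3 to compound 4 (0.39 log units; beyond the scatter), so in this assay this change did not carry over from one core to the other in the same direction: the same change on two cores in this assay, a 3.2-fold lower number (0.50 log units; beyond the scatter) from compound 1 to compound 2 and an at least 2.5-fold higher number (0.39 log units; beyond the scatter) from compound 3 to compound 4, at least 7.8-fold (0.89 log units) apart, beyond the scatter of two such steps

Compound 4 gives > 10000 nM, a limit of the assay and not a number.

The oxygen sits on a saturated ring carbon in this step and on a saturated chain carbon in the earlier one, and the cores differ too, so these two steps cannot separate place from core, nor give the full size of the new step.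

The compounds shown leave open how this ring position behaves on the core of compound 1. They also leave open how a methyl ether or an amine would read there.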